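This account rests on a few compounds, and the source may have more. Where it says the series, first, only, none or still open, it means among the compounds named here.

Of the compounds shown here, three sharing one core have been tested in a functional assay on EC9706 cells (Homo sapiens) for cytotoxicity, read by MTT assay, with a stated time of 72 h; a lower number here means a stronger inhibitor, a higher number a weaker inhibitor. Compound 1 `Cc1ccc(Cn2cc(CSC(=S)N3CCN(C(N)=O)CC3)nn2)cc1` stops at a limit of the assay, > 128000 nM. Compound 2 `CCNC(=O)N1CCN(C(=S)SCc2cn(Cc3ccc(C)cc3)nn2)CC1` likewise gives only a limit, > 128000 nM. Compound 3 `COc1ccc(Cn2cc(CSC(=S)N3CCN(C(N)=O)CC3)nn2)cc1` too returns a limit, > 128000 nM. From compound 1 to compound 2 the change is ethyl in place of hydrogen on an amide-type nitrogen, and the step that the two limits leave unreadable from compound 1 to compound 2 cannot be sized because of the limit of > 128000 nM in this assay, at which 3 of the 3 values shown sit. The cores of compound 1 and compound 3 differ by methoxy in place of methyl on an aromatic carbon, with the step that the two limits leave unreadable from compound 1 to compound 3. Compound 4 `CCNC(=O)N1CCN(C(=S)SCc2cn(Cc3ccc(OC)cc3)nn2)CC1`, not yet measured, carries the same change relative to compound 3, namely (ethyl in place of hydrogen on an amide-type nitrogen). Given that compound 3 gives the limit > 128000 nM, the step from compound 3 to compound 4 is expected to be a step that the limit leaves unreadable from compound 3 to compound 4. Compound 4 is therefore estimated at 150000 nM, within 60000 nM to 400000 nM, most probably reported again only as a limit.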

Compound 4, half-maximal inhibitory concentration: > 128000 nM
Compound 4 ended at the assay's limit; the forecaster's own chance of this, stated with the estimate: 85%; the middle value lies beyond the limit too.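

No new step can be read for compound 4 against compound 3 or compound 2, because all the values stop at a limit: the limit of > 128000 nM in this assay, at which 4 of the 4 values shown sit.

The compounds shown leave open how large either change, ethyl for hydrogen or methoxy for methyl, actually is.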